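The compounds below may be only part of what the source reports. "The series", "measured", "known", "first", "only" and "open" are said of these compounds alone.

For the measured compounds named here, compound 1 `CN1CCN(CC#Cc2cc3ncnc(Nc4ccc(OCc5cccc(F)c5)c(Cl)c4)c3s2)CC1` is the only member of this small set that gives an actual number in an ADME assay on NIH3T3 cells (Mus musculus) for cytotoxicity; on this read-out lower numbers stand for higher toxicity in this test and higher numbers for lower toxicity in this test: there compound 1 gives 4.8 uM. Compound 2 `CN(C)CC#Cc1cc2ncnc(Nc3ccc(OCc4cccc(F)c4)c(Cl)c3)c2s1` reaches only the limit of the assay, so that compound 2 gives > 50 uM. Compound 3 `COCC#Cc1cc2ncnc(Nc3ccc(OCc4cccc(F)c4)c(Cl)c3)c2s1` likewise stops at a limit, and compound 3 gives > 50 uM. Both an at least 10-fold higher number from compound 1 to compound 2 (1.01 log units; beyond the scatter) and an at least 10-fold higher number from compound 1 to compound 3 (1.01 log units; beyond the scatter) show that removing the 4-methylpiperazin-1-yl group moves the number up, to the limit of > 50 uM in this assay, at which 2 of the 3 values shown sit. Compound 4 `CC(C)(C)OC(=O)N1CCC[C@H]1C#Cc1cc2ncnc(Nc3ccc(OCc4cccc(F)c4)c(Cl)c3)c2s1` makes a change of the same kind at the same place: 1-(tert-butoxycarbonyl)pyrrolidin-2-yl in place of (4-methylpiperazin-1-yl)methyl on a triple-bonded carbon. Because an at least 10-fold higher number from compound 1 to compound 2 (1.01 log units; beyond the scatter) and an at least 10-fold higher number from compound 1 to compound 3 (1.01 log units; beyond the scatter) were both large, the expected step is an 8.3-fold higher number from compound 1 to compound 4 (0.92 log units; beyond the scatter). Compound 4 is therefore estimated at 40 uM, within 10 uM to 100 uM.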

Compound 4, half-maximal toxic concentration: > 100 uM
Compound 4: only a limit was reported (the forecaster's own chance of this, stated with the estimate: 60%); at least 2.5-fold (0.39 log units) between middle value and limit.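

In this assay this change on the triple-bonded carbon gives an at least 20-fold higher number from compound 1 to compound 4 (1.31 log units; beyond the scatter) although the entering group holds more heavy atoms than the one leaving. The rise seen with compound 2 and compound 3 therefore also appears with a larger group, one built on a five-membered ring. Compound 4 stops at a limit of its own: the limit of > 100 uM in this assay, at which 1 of the 4 values shown sits.

The steps from compound 2 and from compound 3 to compound 4 cannot be read, so these three compounds cannot be ranked. Also open, on these data alone, is what a pyrrolidin-2-yl group carrying a free amine hydrogen, without the tert-butoxycarbonyl, would give here.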